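A few compounds are considered here, and "the series" means these few. Any claim that something is new, unique, unknown or untested is made for them only; others in the source may bear on it.

Measured in a functional assay on CCRF-CEM cells (Homo sapiens) for cytotoxicity, read by MTT assay, with a stated time of 72 h; on this read-out lower numbers stand for stronger inhibition of growth and higher numbers for weaker inhibition of growth:
compound 1, `CSc1nc(NCCCc2ccccc2)c2ccccc2n1`: 87800 nM
compound 2, `CSc1nc(NCc2ccc([Se]C)cc2)c2ccccc2n1`: only a limit of the assay, > 100000 nM
compound 3, `[SeH]c1nc([SeH])c2cccnc2n1`: "not determined" (no result reported)

Among the measured compounds shown here, compound 1 therefore holds the only number in this assay. Compound 2 sits at a limit, not a number. Compound 3 carries no value at all. No two of these compounds differ in a single place, so no measured step is available to lean on. Compound 4, `CSc1nc(NCCCCc2ccccc2)c2ccccc2n1`, differs from compound 1 by benzyl in place of phenyl on a saturated chain carbon, three bonds along the chain from a nitrogen on an aromatic ring. The chain lengthens while the aromatic end and the shared core stay as they are. With no comparable step shown, the expected step is a 1.0-fold lower number from compound 1 to compound 4 (0.01 log units; within the scatter), no larger than the scatter and in no set direction. Compound 4 is thus estimated at 85000 nM, expected to fall between 35000 nM and 150000 nM.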

Compound 4, concentration for total growth inhibition: > 100000 nM
Compound 4 ended at the assay's limit; the forecaster's own chance of this, stated with the estimate: 35%; middle value at least 1.1-fold (0.07 log units) away from the limit.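

In this assay, benzyl in place of phenyl on a saturated chain carbon gives an at least 1.1-fold higher number from compound 1 to compound 4 (0.05 log units; that floor lies within the scatter), a floor and not a measured size. Compound 4 gives > 100000 nM, which is a limit of the assay and not a number. The longer chain brings no sign of stronger inhibition of growth at this position, and compound 4 joins the compounds at the limit: the limit of > 100000 nM in this assay, at which 2 of the 4 values shown sit.

Going by these compounds, how far compound 4 actually lies from compound 1 remains unknown. On these data alone, whether an amine or a carboxylic acid at the end of the chain, or a shorter chain, would give stronger inhibition of growth also stays open.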